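Swapping isopropyl for ethoxycarbonyl on the aromatic ring

This account rests on a few compounds, and the source may have more. Where it says the series, first, only, none or still open, it means among the compounds named here.

Measured so far:
compound 1, `CCc1cccc(NC(=O)N[C@H](C)c2ccccc2)c1`, 36%
compound 2, `CC(C)c1cccc(NC(=O)N[C@H](C)c2ccccc2)c1`, 44%

In an ADME assay on the whole organism with Oryza sativa as the target, tested at 10 uM (a lower number here means a stronger effect, a higher number a weaker effect of the compound at the concentration tested), compound 1 gives 36% and compound 2 gives 44%. Only these two numbers exist, and the step of a number 8 percentage points higher from compound 1 to compound 2 (within the scatter) shows that the pair cannot be told apart, so compound 2 stands level with compound 1 rather than above or below it.

Compound 3, `CCOC(=O)c1cccc(NC(=O)N[C@H](C)c2ccccc2)c1`, is not yet measured. It differs from compound 2 by ethoxycarbonyl in place of isopropyl on an aromatic carbon. Among the measured compounds shown here, the single measured step, from compound 1 to compound 2, concerns a saturated chain carbon and is within the scatter; it says nothing about replacing one group on the aromatic ring by another. For the measured compounds named here, no measured step therefore bears on the change to compound 3, and there is no basis for expecting movement in either direction beyond the scatter.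

For compound 3 the expected step is a number 1 percentage points higher from compound 2 to compound 3 (within the scatter), a step of essentially no size. The estimate for compound 3 in this assay is 45%, with a broad range from 15% to 80% that reflects how little the data say about this kind of change.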

Compound 3, a percentage reported as activity, at one concentration (the size of the read-out at that concentration, not a potency): 88%
Estimate against measurement, compound 3: 43 percentage points below, outside the stated range (above it).
By their numbers in this assay, from the lowest: compounds 1 and 2 (each within the scatter of the next); then compound 3.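

Ethoxycarbonyl on this aromatic carbon separates clearly from the two plain carbon groups in this assay: ethoxycarbonyl in place of isopropyl gives a number 44 percentage points higher from compound 2 to compound 3 (beyond the scatter) and ethoxycarbonyl in place of ethyl gives a number 52 percentage points higher from compound 1 to compound 3 (beyond the scatter), both steps towards a weaker effect, which makes compound 3 the weakest of the three. The earlier compounds shown here showed no such sensitivity, since ethyl and isopropyl at this place gave numbers within the scatter of each other, so only now is it clear that the group on this aromatic carbon can strongly change the result. Unlike ethyl and isopropyl, ethoxycarbonyl carries oxygen atoms, a double bond and hydrogen-bond acceptors, but nothing available explains which of these differences, if any, lies behind the large steps.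

The compounds shown leave open whether the weaker effect belongs to the whole ester or to a part of it, which a methoxy group, an acetyl group or a carboxylic acid at the same place could begin to separate. They also leave open whether a longer carbon chain such as butyl would stay level with ethyl and isopropyl or move away from them.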